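The compounds below may be only part of what the source reports. "The series", "measured", "known", "first", "only" and "open" are said of these compounds alone.

Working notes on the series.

Three acrylamide-bearing compounds share one core. Compound 1 `C=CC(=O)Nc1cccc(Nc2ncnc(Nc3ccc(C(=O)N4CCCCC4)cc3)n2)c1` carries a (piperidin-1-yl)carbonyl and in a functional assay on Raji cells (Homo sapiens) for antiproliferative activity, read by CCK-8 assay, with a stated time of 24 h (a lower number here means a stronger inhibitor, a higher number a weaker inhibitor), compound 1 gives 5140 nM. Compound 2 `C=CC(=O)Nc1cccc(Nc2ncnc(Nc3ccc(Oc4ccc(OC)cc4)cc3)n2)c1` has no result in this assay: for compound 2 the value is "not determined" (no result reported). Compound 3 `C=CC(=O)Nc1cccc(Nc2ncnc(Nc3ccc(OC)cc3)n2)c1` carries a methoxy at the same position, and in this assay compound 3 gives 14500 nM, the higher of the two numbers shown; the step of a 2.8-fold higher number from compound 1 to compound 3 (0.45 log units; beyond the scatter) is beyond the scatter but modest.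

Compound 4 `C=CC(=O)Nc1cccc(Nc2ncnc(Nc3ccc(-c4ccc(C)nc4)cc3)n2)c1` differs from compound 3 by 6-methylpyridin-3-yl in place of methoxy on an aromatic carbon, that is, on an aromatic carbon of a six-membered aromatic ring of carbon only, para to a large group. For the measured compounds named here, the only measured step that bears on this position is the one from compound 1 to compound 3, where the methoxy gave the higher number. Replacing the methoxy with a larger group is therefore expected to move the number down again, likely by a modest amount, so the step of a 3.2-fold lower number from compound 3 to compound 4 (0.51 log units; beyond the scatter) is the estimate here. For compound 4 the expected value in this assay is 4500 nM, with a range from 1500 nM to 14000 nM.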

Compound 4, half-maximal inhibitory concentration: 13800 nM
Compound 4: the middle estimate sits 3.1-fold (0.49 log units) below what was measured, within the range that was stated.
By their numbers in this assay, from the lowest: compound 1; then compounds 4 and 3 (each within the scatter of the next).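

In this assay, 6-methylpyridin-3-yl in place of methoxy on this aromatic carbon gives a 1.1-fold lower number from compound 3 to compound 4 (0.02 log units; within the scatter), so a group of 2 heavy atoms and a ring-bearing group of 7 heavy atoms read alike here, and a larger group at this position does not by itself bring the number down. The (piperidin-1-yl)carbonyl of compound 1 now stands apart from both groups, with a 2.7-fold higher number from compound 1 to compound 4 (0.43 log units; beyond the scatter) matching in size the earlier 2.8-fold higher number from compound 1 to compound 3 (0.45 log units; beyond the scatter) and no longer resting on the methoxy alone. Nothing on hand accounts for why these groups read as they do.

From the compounds shown here alone, whether an amine or a carboxylic acid on this aromatic carbon would separate from these numbers stays open, as does whether the carbonyl or the piperidine carries the difference seen for compound 1. Compound 2 has no number, so steps to it cannot be read.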